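Thiazolylamine in Place of Cyclopropylmethylamine on the Shared Core

The source may report more compounds than this note shows. Statements on the series, on what has been measured and on what is new or still open speak of the compounds shown alone.

Compound 3 `Cc1nc(NCC2CC2)nc(N[C@@H]2C[C@H](CO)[C@@H](O)[C@H]2O)c1-c1nc2ccccc2s1` stands at the lower end of the two numbers recorded so far. In an ADME assay on cells (Homo sapiens) for cytotoxicity, read by polymerase chain reaction, with a stated time of 3 days (a higher number here means that more compound is tolerated, a lower number that less compound is tolerated), compound 3 gives 8000 nM. Compound 2 `Nc1nc(Cl)c(-c2nc3ccccc3s2)c(N[C@@H]2C[C@H](CO)[C@@H](O)[C@H]2O)n1` gives 14000 nM in this assay, and the gap between compound 2 and compound 3 lies within the scatter, so no order between them can be claimed. Compound 1 `Nc1nc(Cl)c(-c2cc3ccccc3s2)c(N[C@@H]2C[C@H](CO)[C@@H](O)[C@H]2O)n1` reaches only a limit in this assay, > 25000 nM, and that limit is recorded as the limit of > 25000 nM in this assay, at which 1 of the 3 values shown sits.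

Compound 4 `Cc1nc(Nc2nccs2)nc(N[C@@H]2C[C@H](CO)[C@@H](O)[C@H]2O)c1-c1nc2ccccc2s1` differs from compound 3 in one place: 1,3-thiazol-2-yl in place of cyclopropylmethyl on a nitrogen on an aromatic ring. For the measured compounds named here, the only measured step, an at least 1.7-fold lower number from compound 1 to compound 2 (0.25 log units; that floor lies within the scatter), concerns the exchange of 1-benzothiophen-2-yl for 1,3-benzothiazol-2-yl on an aromatic carbon, not a change on a nitrogen on an aromatic ring, and it lies within the scatter anyway; it offers no direct guide here. Going by the values given here, with no step on this kind of change in hand, compound 4 is expected to stay within the scatter of compound 3, the estimated step being no change at the digits printed from compound 3 to compound 4 (within the scatter). Compound 4 is therefore expected to give 8000 nM in this assay, within a range from 3000 nM to 22000 nM.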

Compound 4, half-maximal cytotoxic concentration: 15000 nM
Compound 4: middle estimate off by 1.9-fold (0.27 log units), on the low side; low and high end bracket the measured number.
By their numbers in this assay, from the lowest: compounds 3, 2 and 4 (each within the scatter of the next). At a limit, above all of these: compound 1.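

In this assay, for the compounds shown here, putting 1,3-thiazol-2-yl in place of cyclopropylmethyl on a nitrogen on an aromatic ring gives a 1.9-fold higher number from compound 3 to compound 4 (0.27 log units; within the scatter), and this is the first reading of any change at this position. The earlier step concerned a group on an aromatic carbon, whereas this one shows that a five-membered aromatic ring with 2 hetero atoms can replace a group with a three-membered non-aromatic ring without a change that stands clear of the scatter. Nothing on hand bears on the cause of this small step.

The compounds shown leave open whether a longer chain, a morpholine or a pyridine ring on this nitrogen would take the number beyond the scatter. They also leave open whether the same exchange would read alike on the core of compound 2.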